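The source may hold more compounds than are shown below. What is called first, only, known or untested is meant among the compounds shown, and "the series" means these compounds.

Compound 1 `Oc1ccc(-c2cc(-c3ccco3)cc(-c3cccc(O)c3)n2)cc1` was tested in a functional assay on T47D cells (Homo sapiens) for cytotoxicity, read by CCK-8 assay (on this read-out lower numbers stand for stronger inhibition and higher numbers for weaker inhibition), where compound 1 gives 1280 nM. Of the two compounds measured, compound 1 has the lowest number. For the measured compounds named here, its only measured neighbour is compound 2 `Oc1ccc(-c2cc(-c3ccco3)cc(-c3ccc(O)cc3)n2)cc1`, which in this assay gives 21100 nM; the step of a 16-fold higher number from compound 1 to compound 2 (1.22 log units; beyond the scatter) is large, and it comes from swapping one hydroxyphenyl for another.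

Compound 3 `Oc1ccc(-c2cc(-c3ccoc3)cc(-c3cccc(O)c3)n2)cc1` has not yet been measured. It differs from compound 1 only in the way the furan ring is attached: furan-3-yl in place of furan-2-yl on an aromatic carbon. Going by the values given here, no measured step touches the furan, so the one step that exists, the change from compound 1 to compound 2, says nothing about this particular change. With nothing to point either way, compound 3 is expected to land close to compound 1, with a step from compound 1 to compound 3 that is estimated at a 1.3-fold higher number from compound 1 to compound 3 (0.10 log units; within the scatter), not beyond the scatter. The estimate for compound 3 in this assay is therefore 1600 nM, in the range 500 nM to 5500 nM.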

Compound 3, half-maximal inhibitory concentration: 2610 nM
Compound 3: the middle estimate sits 1.6-fold (0.21 log units) below what was measured; the range from low to high includes it.
By their numbers in this assay, from the lowest: compound 1; then compound 3; then compound 2.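

In this assay, moving only the point of attachment of the furan, with the same atoms and the same counted features, gives a 2.0-fold higher number from compound 1 to compound 3 (0.31 log units; beyond the scatter). This shows that the position opposite the ring nitrogen responds to how the ring is joined and not just to which atoms it contains, although the step is modest and compound 1 keeps the lowest number of the three. No measurement here explains why furan-2-yl gives the lower number of this pair.

The compounds shown leave open whether a different group at this place, such as thiophene, an amine or a short alkyl chain, would keep the number close to that of compound 1. They also leave open whether furan-3-yl would produce a similar step on the two 4-hydroxyphenyl groups of compound 2.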